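The source may report more compounds than this note shows. Statements on the series, on what has been measured and on what is new or still open speak of the compounds shown alone.

Working notes on the series. The compounds share one core and differ at two positions. Compound 2 `N=C(N)N/N=C/c1c(-c2ccccn2)nc2sc(Cl)cn12` gives 8910 nM in a functional assay (Homo sapiens) for antiproliferative activity; a higher number here means a weaker inhibitor of growth, a lower number a stronger inhibitor of growth. Compound 3 `N=C(N)N/N=C/c1c(-c2ccncc2)nc2sc(Cl)cn12` gives 13200 nM in this assay. Compound 1 `Cc1cn2c(/C=N/NC(=N)N)c(-c3ccncc3)nc2s1` gives 34700 nM in this assay. The cores of compound 2 and compound 3 differ by pyridin-2-yl in place of pyridin-4-yl on an aromatic carbon, and the measured step is a 1.5-fold higher number from compound 2 to compound 3 (0.17 log units; within the scatter). Compound 4 `Cc1cn2c(/C=N/NC(=N)N)c(-c3ccccn3)nc2s1` has not yet been measured in this assay. It differs from compound 2 by methyl in place of chloro on an aromatic carbon. The same change, made on the core of compound 3, is methyl in place of chloro on an aromatic carbon and produced the step of a 2.6-fold higher number from compound 3 to compound 1 (0.42 log units; beyond the scatter); the two places are described in identical words, so the change counts as the same one made twice. For the measured compounds named here, only this single measured instance speaks to the change, and none on the core of compound 2. The expected step, set beside a 2.6-fold higher number from compound 3 to compound 1 (0.42 log units; beyond the scatter), is a 2.6-fold higher number from compound 2 to compound 4 (0.41 log units; beyond the scatter), resting on compound 2 at 8910 nM and carried over because a 1.5-fold higher number from compound 2 to compound 3 (0.17 log units; within the scatter) lies within the scatter. Compound 4 is therefore estimated at 23000 nM in this assay, with most repeats expected between 11000 nM and 50000 nM.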

Compound 4, concentration for 50% growth inhibition: 8910 nM
Compound 4: middle estimate off by 2.6-fold (0.41 log units), on the high side, and the stated range ends above it.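

In this assay, methyl in place of chloro on an aromatic carbon gives no change at the digits printed from compound 2 to compound 4 (within the scatter), and the gap to the step on the other core stays within what scatter alone allows: the same change on two cores in this assay, a 2.6-fold higher number (0.42 log units; beyond the scatter) from compound 3 to compound 1 and no change at the digits printed (within the scatter) from compound 2 to compound 4, 2.6-fold (0.42 log units) apart, within the scatter of two such steps. Pyridin-2-yl in place of pyridin-4-yl on an aromatic carbon gives a 3.9-fold lower number from compound 1 to compound 4 (0.59 log units; beyond the scatter), and this change too shows no gap beyond the scatter when set beside its earlier step: the same change on two cores in this assay, a 1.5-fold higher number (0.17 log units; within the scatter) from compound 2 to compound 3 and a 3.9-fold higher number (0.59 log units; beyond the scatter) from compound 4 to compound 1, 2.6-fold (0.42 log units) apart, within the scatter of two such steps. For the compounds shown here, these four compounds therefore give no firm sign that either change behaves differently from one core to the other, but they do not show that the steps carry over unchanged, since each change has been seen on only two cores and the steps themselves are small.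

As far as these compounds go, whether an amine, a carboxylic acid or a longer chain in place of chloro would follow the same steps remains open. Also open, from the compounds shown here alone, is how a phenyl ring in place of the pyridinyl ring would read in this assay.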